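The source may report more compounds than this note shows. Statements on the series, on what has been measured and on what is new or still open speak of the compounds shown alone.

Compound 3 `COc1cc(C)c(C(=O)N=C(N)N)cc1S(C)(=O)=O` gives 16 nM in a functional assay for inhibition of sodium/hydrogen exchanger (Oryctolagus cuniculus); on this read-out higher numbers stand for weaker inhibition and lower numbers for stronger inhibition. Among the three measured compounds it stands second highest; its nearest neighbour is compound 2 `Cc1cc(C2CCCCC2)c(S(C)(=O)=O)cc1C(=O)N=C(N)N`, which gives 22 nM, and the step of a 1.4-fold lower number from compound 2 to compound 3 (0.14 log units; within the scatter) lies within the scatter. Compound 1 `CCC(C)c1cc(C)c(C(=O)N=C(N)N)cc1S(C)(=O)=O` gives 8 nM, and the step of a 2.0-fold higher number from compound 1 to compound 3 (0.30 log units; within the scatter) is also within the scatter. Compound 4 `Cc1cc(Nc2ccccc2)c(S(C)(=O)=O)cc1C(=O)N=C(N)N` differs from compound 3 by anilino in place of methoxy on an aromatic carbon. The two steps that alter this same position were both small, and compound 2 also carries a six-membered ring there, so one expects no step beyond the scatter in this assay. For compound 4 the estimate is 25 nM, between 8 nM and 80 nM, an expected step of a 1.6-fold higher number from compound 3 to compound 4 (0.19 log units; within the scatter).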

Compound 4, half-maximal inhibitory concentration: 21 nM
Compound 4: middle estimate off by 1.2-fold (0.08 log units), on the high side; the measured number falls inside the stated range.
By their numbers in this assay, from the lowest: compounds 1, 3, 4 and 2 (each within the scatter of the next, the first and the last beyond it).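

In this assay anilino, which brings a hydrogen-bond donor and an aromatic ring to this position, stays within the scatter of methoxy (a 1.3-fold higher number from compound 3 to compound 4 (0.12 log units; within the scatter)) and of cyclohexyl (a 1.0-fold lower number from compound 2 to compound 4 (0.02 log units; within the scatter)). Only the comparison with sec-butyl passes the scatter, and modestly (a 2.6-fold higher number from compound 1 to compound 4 (0.42 log units; beyond the scatter)). Among the compounds shown, the position thus accepts quite different groups with little spread, compound 1 being the exception, and nothing available explains this. Going by these compounds, how a primary amine or a carboxylic acid would behave here remains open, as does the role of the anilino hydrogen, which a methylated anilino group would test.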